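The source may report more compounds than this note shows. Statements on the series, on what has been measured and on what is new or still open speak of the compounds shown alone.

Measured compounds:
Compound 1 `C/C=C(/C)C#Cc1ccc(CCC(=O)O)c(F)c1` — in a functional assay on 1321-N1 cells for agonist activity at Free fatty acid receptor 1 (Homo sapiens), read by calcium flux, with a stated time of 0.4 s (a lower number here means a smaller maximal response, a higher number a larger maximal response), compound 1 gives 103%
Compound 2 `O=C(O)CCc1ccc(C#CC2CC2)cc1` — in this assay compound 2 gives 128%

Compound 1 stands at the lowest of the two numbers. Its nearest neighbour is compound 2, whose number is higher by a gap that lies beyond the usual scatter; the two compounds differ in more than one place, so their two values are all that can be said of the pair.

The step followed here leads from compound 1 to compound 3 `C/C(C#Cc1ccc(CCC(=O)O)c(F)c1)=C/CO`. The change is hydroxy in place of hydrogen on a saturated chain carbon bound to a double-bonded chain carbon. Among the compounds with values here, no step between two measured compounds that differ in one place is available to show how such a change plays out in this assay, so the expectation rests on compound 1 alone.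

With a single hydroxy entering in place of a hydrogen, the maximal response is expected to stay close to that of compound 1, with a step of a number 3 percentage points lower from compound 1 to compound 3 (within the scatter) that could run in either direction but is not expected to pass beyond the scatter. Compound 3 is therefore estimated to give 100%, expected to fall between 80% and 125%.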

Compound 3, largest response reached (reported as efficacy), in percent of the reference or control that the assay uses: 105%
Beside the measured number, compound 3's estimate is 5 percentage points below it, and the stated range covers the measured number.
By their numbers in this assay, from the lowest: compounds 1 and 3 (each within the scatter of the next); then compound 2.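

Within the data shown here, measured in this assay, the change from methyl to hydroxymethyl gives a number 2 percentage points higher from compound 1 to compound 3 (within the scatter) and offers the first direct reading at this position, on a saturated chain carbon bound to a double-bonded chain carbon. In this one pair, the added hydroxy, with its one hydrogen-bond donor and one hydrogen-bond acceptor, leaves the two compounds indistinguishable by their largest response, so this position can carry the group without a loss that stands out from the scatter. The data offer no further measurement that could explain why the pair reads alike.

From the compounds shown here alone, it remains open whether this position would accept other groups equally well, such as a methoxy, an amine, a carboxylic acid, or a longer chain ending in hydroxy. Going by these compounds, it is also open whether this single pair speaks for other cores, such as that of compound 2, and whether the concentration needed to reach the largest response would follow the same course.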